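Working notes: aryl exchange towards compound 4

The source may report more compounds than this note shows. Statements on the series, on what has been measured and on what is new or still open speak of the compounds shown alone.

Measured values in a functional assay on MCF7 cells (Homo sapiens) for antiproliferative activity, read by MTT assay, with stated times of 24 h and 72 h (on this read-out lower numbers stand for stronger inhibition and higher numbers for weaker inhibition), are as follows:
- compound 1 `COc1ccc([C@@H]2[C@H](Oc3ccccc3)C(=O)N2c2cc(OC)c(OC)c(OC)c2)cc1[N+](=O)[O-]` gives 69000 nM
- compound 2 `COc1cc(N2C(=O)[C@@H](Oc3ccccc3)[C@H]2c2ccc(S(C)(=O)=O)cc2)cc(OC)c1OC` gives 62000 nM
- compound 3 `COc1cc(N2C(=O)[C@@H](Oc3ccccc3)[C@H]2c2cccc(O)c2)cc(OC)c1OC` gives 54000 nM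

Compound 3 at 54000 nM lies within the scatter of both other compounds and holds no separate place among them. The next structure is compound 4 `COc1ccc([C@@H]2[C@H](Oc3ccccc3)C(=O)N2c2cc(OC)c(OC)c(OC)c2)cc1N`. The change is 3-amino-4-methoxyphenyl in place of 3-hydroxyphenyl on a saturated ring carbon and it falls on a saturated ring carbon of a four-membered non-aromatic ring.

Three measured steps exchange the group on this same carbon. They are a 1.1-fold lower number from compound 1 to compound 2 (0.05 log units; within the scatter) and a 1.3-fold lower number from compound 1 to compound 3 (0.11 log units; within the scatter) and a 1.1-fold lower number from compound 2 to compound 3 (0.06 log units; within the scatter) and all of them stay within the scatter. On these steps alone, no large step is expected in this assay for the new group. However, no measured compound carries 3-amino-4-methoxyphenyl, so the data cannot exclude a larger step. A moderately lower number is expected, and the range is left wide on the lower side. The estimate means a 4.5-fold lower number from compound 3 to compound 4 (0.65 log units; beyond the scatter) as an expected step. Compound 4 is estimated at 12000 nM with an expected range from 200 nM to 70000 nM in this series.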

Compound 4, half-maximal inhibitory concentration: 12200 nM
Estimate against measurement, compound 4: 1.0-fold (0.01 log units) below, within the range that was stated.
By their numbers in this assay, from the lowest: compound 4; then compounds 3, 2 and 1 (each within the scatter of the next).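

In this assay the group on the saturated ring carbon now gives steps beyond the scatter, with a 4.4-fold lower number from compound 3 to compound 4 (0.65 log units; beyond the scatter) and a 5.1-fold lower number from compound 2 to compound 4 (0.71 log units; beyond the scatter) as the two aryl exchanges, whereas the earlier exchanges at this carbon all stayed within it. The closest comparison is a 5.7-fold lower number from compound 1 to compound 4 (0.75 log units; beyond the scatter) with only amino in place of nitro on an aromatic carbon, so the difference between these two compounds lies in that single group. Compound 4 is thus the only compound here whose steps to all the others lie beyond the scatter, and the data shown offer no measurement that explains this.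

On these data alone, it remains open whether dimethylamino or acetamido in place of amino would keep this step. The compounds shown also leave open whether 3-aminophenyl, without the methoxy group, would do the same.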